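Swapping methoxy for chloro on compound 2

The source may hold more compounds than are shown below. What is called first, only, known or untested is meant among the compounds shown, and "the series" means these compounds.

Three compounds sharing a common core have been taken into an ADME assay on HEK293 cells (Homo sapiens) for cytotoxicity, read by MTT assay, with a stated time of 48 h (a higher number here means a weaker inhibitor, a lower number a stronger inhibitor), so far. For compound 1 (`COc1ccc(-c2nc(C)c(C(=O)CSc3nc(-c4ccc(OC)cc4)c(C#N)c(=O)[nH]3)s2)cc1`) the entry reads "not determined" (no result reported) and offers no number to work with. Compound 2 (`COc1ccc(-c2nc(C)c(C(=O)CSc3nc(-c4cccc(OC)c4)c(C#N)c(=O)[nH]3)s2)cc1`) gives 95400 nM as the higher of the two numbers available. Compound 3 (`COc1ccc(-c2nc(C)c(C(=O)CSc3nc(-c4ccc(Cl)c(Cl)c4)c(C#N)c(=O)[nH]3)s2)cc1`) gives 45600 nM as the other.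

The next molecule is compound 4 (`COc1cccc(-c2nc(SCC(=O)c3sc(-c4ccc(Cl)cc4)nc3C)[nH]c(=O)c2C#N)c1`), which departs from compound 2 in a single place: chloro in place of methoxy on an aromatic carbon with chloro in place of methoxy on an aromatic carbon, so that 4-methoxyphenyl becomes 4-chlorophenyl. Among the compounds with values here, only one measured step bears on this change. It is a 2.1-fold lower number from compound 2 to compound 3 (0.32 log units; beyond the scatter) with 3,4-dichlorophenyl in place of 3-methoxyphenyl. That step is modest and also trades methoxy for chloro, but it lies on a different aromatic ring, so it is only a loose guide. The expected change is a 1.5-fold lower number from compound 2 to compound 4 (0.17 log units; within the scatter) in the same direction as that step and no larger than it. In this assay the estimated value for compound 4 is 65000 nM with an expected range from 32000 nM to 130000 nM as its upper end.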

Compound 4, half-maximal inhibitory concentration: 77900 nM
For compound 4 the middle estimate is 1.2-fold (0.08 log units) below the measured one, and the stated range covers the measured number.
By their numbers in this assay, from the lowest: compounds 3, 4 and 2 (each within the scatter of the next, the first and the last beyond it).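

In this assay, the exchange of 4-methoxyphenyl for 4-chlorophenyl gives a 1.2-fold lower number from compound 2 to compound 4 (0.09 log units; within the scatter), so chloro and methoxy cannot be told apart at this place, para to a large group, in this read-out. The earlier step, a 2.1-fold lower number from compound 2 to compound 3 (0.32 log units; beyond the scatter), concerned a different aromatic ring and put 3,4-dichlorophenyl in place of 3-methoxyphenyl, so it said nothing direct about this position. The new pair shows that here a methoxy, with its 2 heavy atoms and 1 hydrogen-bond acceptor, can give way to a chloro, with 1 heavy atom and no hydrogen-bond acceptor, while the number stays within the usual scatter, and no measurement at hand offers an explanation for this result.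

The compounds shown leave open whether a quite different group at this position, such as an amine, a carboxylic acid or a longer alkoxy chain, would move the number beyond the scatter. They also leave open how the 4-chlorophenyl and 3,4-dichlorophenyl changes would behave together in a single molecule.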